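Swapping the oxazole of compound 3 for a methylpyrazole

This account rests on a few compounds, and the source may have more. Where it says the series, first, only, none or still open, it means among the compounds named here.

compound 1 `CCCNC(=O)c1ccc(Oc2nc(-c3c(C)noc3C)cnc2N)cc1` — 6880 nM
compound 2 `Cc1noc(C)c1-c1cnc(N)c(Oc2ccc(C(=O)Nc3cccc(Cl)c3)cc2)n1` — 7300 nM
compound 3 `Cc1noc(C)c1-c1cnc(N)c(Oc2ccc(C(=O)Nc3ncccc3Cl)cc2)n1` — 27200 nM

Of the compounds shown here, three have been measured in a functional assay on HepG2 cells (Homo sapiens) for inhibition, read by MTT assay, with a stated time of 72 h; on this read-out lower numbers stand for stronger inhibition and higher numbers for weaker inhibition. Compound 3 stands highest of the three: a 3.7-fold higher number from compound 2 to compound 3 (0.57 log units; beyond the scatter) and a 4.0-fold higher number from compound 1 to compound 3 (0.60 log units; beyond the scatter), both modest steps, while a 1.1-fold higher number from compound 1 to compound 2 (0.03 log units; within the scatter). Compound 4 `Cn1cc(-c2cnc(N)c(Oc3ccc(C(=O)Nc4ncccc4Cl)cc3)n2)cn1` differs from compound 3 in one place: 1-methyl-1H-pyrazol-4-yl in place of 3,5-dimethyl-1,2-oxazol-4-yl on an aromatic carbon. Going by the values given here, all three measured steps change only the group on the amide-type nitrogen; none alters the aromatic carbon where compound 4 differs, so no measured step bears on this change. With nothing to guide the size or direction, compound 4 is expected to give about the same number as its parent, which means an estimated step of a 1.0-fold lower number from compound 3 to compound 4 (0.00 log units; within the scatter), with a wide range. The estimate for compound 4 is 27000 nM, from 8000 nM to 90000 nM.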

Compound 4, half-maximal inhibitory concentration: 21700 nM
Compound 4: the middle estimate sits 1.2-fold (0.09 log units) above what was measured; the range from low to high includes it.
By their numbers in this assay, from the lowest: compounds 1 and 2 (each within the scatter of the next); then compounds 4 and 3 (each within the scatter of the next).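

In this assay, going by these compounds alone, 1-methyl-1H-pyrazol-4-yl in place of 3,5-dimethyl-1,2-oxazol-4-yl on the aromatic carbon gives a 1.3-fold lower number from compound 3 to compound 4 (0.10 log units; within the scatter), the only measured step at this position, since the earlier steps all change the amide-type nitrogen. With the 3-chloropyridin-2-yl amide held fixed, the two five-membered rings read alike here. Nothing available explains this result.

The compounds shown leave open whether the same swap reads alike with the propyl or 3-chlorophenyl amides. They also leave open how an amine or a carboxylic acid on this aromatic carbon would read.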